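Removing one ring methyl from compound 1

This account rests on a few compounds, and the source may have more. Where it says the series, first, only, none or still open, it means among the compounds named here.

Compound 1 `COC(=O)Cn1nc2c(n1)C(=O)C(C)=C(C)C2=O` gives 4 ug/mL in a functional assay on KB cells (Homo sapiens) for inhibition, read by colorimetric assay, with a stated time of 72 h; on this read-out higher numbers stand for an effect only at larger amounts of compound and lower numbers for an effect already at smaller amounts. For the measured compounds named here, compound 3 `COC(=O)C(C)n1nc2c(n1)C(=O)C(C)=C(C)C2=O` gives 3.5 ug/mL in this assay, and the step of a 1.1-fold lower number from compound 1 to compound 3 (0.06 log units; within the scatter) is the only single-point change measured. Compound 2 `Cc1cc2c(cc1C)[n+]([O-])nn2C` reaches only a limit, > 100 ug/mL. Among the two actual numbers, compound 1 sits at the higher one, with compound 3 nearest and within the scatter, so no order between them can be claimed. Compound 4 `COC(=O)Cn1nc2c(n1)C(=O)C(C)=CC2=O` is not yet measured; it differs from compound 1 by hydrogen in place of methyl on a double-bonded ring carbon. Going by the values given here, no measured step touches the ring carbons of the shared core, and the one measured change, on the chain, moved nothing beyond the scatter. For compound 4, then, the estimate in this assay is 4 ug/mL, from 2 ug/mL to 8 ug/mL, a step of no change at the digits printed from compound 1 to compound 4 (within the scatter) expected to stay within the scatter.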

Compound 4, concentration for half-maximal effect: 1.5 ug/mL
Beside the measured number, compound 4's estimate is 2.7-fold (0.43 log units) above it; the measured number lies below the stated range.
By their numbers in this assay, from the lowest: compound 4; then compounds 3 and 1 (each within the scatter of the next). At a limit, above all of these: compound 2.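

In this assay, for the compounds shown here, the double-bonded ring carbon is the first place on the shared core where a single change goes beyond the scatter: hydrogen in place of methyl gives a 2.7-fold lower number from compound 1 to compound 4 (0.43 log units; beyond the scatter). Going by these compounds alone, the only earlier step, on the saturated chain carbon, stayed within the scatter, so this ring position responds where that chain carbon did not. Nothing measured here gives a cause for this step.

Going by these compounds, what an ethyl group, a chlorine or an amine would do at this ring carbon stays open. Also open, on these data alone, is whether losing the remaining ring methyl, or making the same change on compound 3, gives a step of like size.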